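From cyclopropyl to chloro on a shared core

This account rests on a few compounds, and the source may have more. Where it says the series, first, only, none or still open, it means among the compounds named here.

Values so far in an ADME assay on LLC-PK1 cells (Sus scrofa) for permeability, read by LC-MS, with a stated time of 2 h, tested at 5 uM (a higher number here means that the compound crosses the layer faster, a lower number that the compound crosses the layer more slowly), for three compounds
- compound 1 `COc1cc2c(cn1)Oc1ccc(NC(=O)c3ccc(Cl)cn3)cc1[C@@]21COC(N)=N1` gives 25 nm/s
- compound 2 `CC#Cc1cncc(-c2ccc3c(c2)[C@@]2(COC(N)=N2)c2cc(C4=CCCOC4)ncc2O3)c1` gives 19 nm/s
- compound 3 `NC1=N[C@@]2(CO1)c1cc(NC(=O)c3ccc(Cl)cn3)ccc1Oc1cnc(C3CC3)cc12` gives 29 nm/s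

Compound 3 at 29 nm/s lies within the scatter of both other compounds. Compound 4 `NC1=N[C@@]2(CO1)c1cc(NC(=O)c3ccc(Cl)cn3)ccc1Oc1cnc(Cl)cc12` carries chloro in place of cyclopropyl on an aromatic carbon and otherwise matches compound 3. Among the measured compounds shown here, the only measured step at this place, cyclopropyl in place of methoxy, is a 1.2-fold higher number from compound 1 to compound 3 (0.06 log units; within the scatter) and offers a single, thin guide, since chloro has not yet been measured on this core. No step beyond the scatter is expected, and the estimated change is a 1.1-fold lower number from compound 3 to compound 4 (0.05 log units; within the scatter) in this reading. Compound 4 is expected at 26 nm/s in this assay with 13 nm/s to 50 nm/s as the estimated range.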

Compound 4, apparent permeability: 28 nm/s
Beside the measured number, compound 4's estimate is 1.1-fold (0.03 log units) below it, within the range that was stated.
By their numbers in this assay, from the lowest: compounds 2, 1, 4 and 3 (each within the scatter of the next).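

Measured by this assay on the shared core, chloro in place of cyclopropyl gives a 1.0-fold lower number from compound 3 to compound 4 (0.02 log units; within the scatter) and chloro in place of methoxy gives a 1.1-fold higher number from compound 1 to compound 4 (0.05 log units; within the scatter) as its two new steps. Cyclopropyl, methoxy and chloro therefore cannot be told apart at this position by this read-out. No measurement at hand offers a reason for this sameness.

From the compounds shown here alone, whether an amine, a carboxylic acid or a longer chain at this place would move the number beyond the scatter remains open.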